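Swapping Azido for Amino on the Shared Core

The compounds below may be only part of what the source reports. "The series", "measured", "known", "first", "only" and "open" are said of these compounds alone.

In a functional assay on ML1 cells (Homo sapiens) for antiproliferative activity, read by WST assay, with a stated time of 3 days (on this read-out lower numbers stand for stronger inhibition and higher numbers for weaker inhibition), compound 1 `O=c1[nH]c(=O)n([C@@H]2O[C@H](CO)[C@@H](O)[C@H]2O)c(I)c1F` gives only a limit, > 50000 nM. Going by the values given here, compound 2 `[N-]=[N+]=Nc1c(F)c(=O)[nH]c(=O)n1[C@@H]1O[C@H](CO)[C@@H](O)[C@H]1O` gives 600 nM, the only true number so far, so it cannot yet be ranked among measured values. Compound 3 `Nc1c(F)c(=O)[nH]c(=O)n1[C@@H]1O[C@H](CO)[C@@H](O)[C@H]1O` keeps the shared core but carries amino in place of azido on an aromatic carbon, (amino in place of azido on an aromatic carbon).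

Among the compounds with values here, only one measured step bears on this change: an at least 83-fold lower number from compound 1 to compound 2 (1.92 log units; beyond the scatter). That large step shows that the group at this place can move the number strongly. However, it brought azido in and tells nothing directly about amino. Losing azido may therefore give back part of that gain, though probably not all of it. The expected change, toward weaker inhibition, is a 3.3-fold higher number from compound 2 to compound 3 (0.52 log units; beyond the scatter). For compound 3, the estimated value is 2000 nM, with an expected range of 300 nM to 20000 nM.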

Compound 3, half-maximal inhibitory concentration: 700 nM
Beside the measured number, compound 3's estimate is 2.9-fold (0.46 log units) above it, and the stated range covers the measured number.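

In this assay, trading azido for amino makes no change that can be told apart from ordinary scatter: a 1.2-fold higher number from compound 2 to compound 3 (0.07 log units; within the scatter). The large gain seen earlier therefore does not depend on azido itself, since amino, with a single nitrogen where azido has three, also stands well clear of iodo: an at least 71-fold lower number from compound 1 to compound 3 (1.85 log units; beyond the scatter). Compound 1 gives only a limit, so the full size of both steps away from iodo stays unknown: the limit of > 50000 nM in this assay, at which 1 of the 3 values shown sits.

On these data alone, both active compounds carry a group attached through nitrogen, so it remains open whether that nitrogen matters or whether removing iodo is enough. A hydroxyl or methyl group at this place could separate those two readings, and a dimethylamino group would show whether the hydrogens on amino can be replaced.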